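Benzothiazole for Benzimidazole on an Acylthiourea Scaffold

This account rests on a few compounds, and the source may have more. Where it says the series, first, only, none or still open, it means among the compounds named here.

Measured compounds:
compound 1, `N#Cc1ccc2[nH]c(-c3cccc(NC(=S)NC(=O)c4ccc5c(c4)OCCO5)c3)nc2c1`, "not determined" (no result reported) in a functional assay on HUVEC cells (Homo sapiens) for inhibition, read by colorimetric assay and crystal violet staining, with a stated time of 72 h; a lower number here means a stronger inhibitor, a higher number a weaker inhibitor
compound 2, `O=C(NC(=S)Nc1cccc(-c2nc3ccccc3[nH]2)c1)c1ccc2c(c1)OCCO2`, < 100 nM

Two compounds carry the same acylthiourea linker and dioxane-fused benzoyl end. For compound 1 `N#Cc1ccc2[nH]c(-c3cccc(NC(=S)NC(=O)c4ccc5c(c4)OCCO5)c3)nc2c1` no result was reported in this assay, so only compound 2 `O=C(NC(=S)Nc1cccc(-c2nc3ccccc3[nH]2)c1)c1ccc2c(c1)OCCO2` gives information. For compound 2 the reported result is a limit of the assay, < 100 nM, not a single number, and this is the only place among the two entries where a value sits (the limit of < 100 nM in this assay, at which 1 of the 2 values shown sits). Compound 3 `O=C(NC(=S)Nc1cccc(-c2nc3ccccc3s2)c1)c1ccc2c(c1)OCCO2` is not yet measured; it differs from compound 2 in one place: 1,3-benzothiazol-2-yl in place of 1H-benzimidazol-2-yl on an aromatic carbon. Going by the values given here, because no step between two measured compounds is known here, the size of this change can only be guessed; a modest weakening, or none beyond the scatter, is expected. The potency of compound 3 is therefore estimated at 120 nM, within 25 nM to 600 nM, and the expected step is an at least 1.2-fold higher number from compound 2 to compound 3 (0.07 log units; that floor lies within the scatter).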

Compound 3, half-maximal inhibitory concentration: 2600 nM
Compound 3: the middle estimate sits 22-fold (1.34 log units) below what was measured; measured number outside the range, above it.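

In this assay, the change at this position is far from neutral: 1,3-benzothiazol-2-yl in place of 1H-benzimidazol-2-yl gives an at least 26-fold higher number from compound 2 to compound 3 (1.41 log units; beyond the scatter), a large loss of potency from swapping one two-ring group for another with the same ring types. On these data alone, the true size of the step remains unknown, since the value for compound 2 is a limit of the assay and not a single number: the limit of < 100 nM in this assay, at which 1 of the 3 values shown sits. The swap also exchanges a ring nitrogen carrying a hydrogen-bond donor for a sulfur, so the donor count and the atom change together.

These two changes cannot be separated here; a 1-methyl-1H-benzimidazol-2-yl group, which keeps both nitrogens but carries no such hydrogen, would pull them apart. Any step involving compound 1 and its nitrile cannot be read.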